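Nitro to methyl on the aryl triazole ester

The source may report more compounds than this note shows. Statements on the series, on what has been measured and on what is new or still open speak of the compounds shown alone.

Measured in an ADME assay on L132 cells (Homo sapiens) for cytotoxicity, read by MTT assay, with a stated time of 48 h; on this read-out higher numbers stand for weaker inhibition and lower numbers for stronger inhibition:
- compound 1 `C/C(=C\CC/C(C)=C/CC[C@@H]1[C@@]2(C)CCC(=O)C(C)(C)[C@H]2CC[C@@]1(C)O)CC/C=C(\C)C(=O)OCc1cn(-c2ccc([N+](=O)[O-])cc2)nn1`: > 150000 nM (a limit)
- compound 2 `C/C(=C\CC/C(C)=C/CC[C@@H]1[C@@]2(C)CCC(=O)C(C)(C)[C@H]2CC[C@@]1(C)O)CC/C=C(\C)C(=O)OCc1cn(-c2ccccc2[N+](=O)[O-])nn1`: > 150000 nM (a limit)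
- compound 3 `C/C(=C\CC/C(C)=C/CC[C@@H]1[C@@]2(C)CCC(=O)C(C)(C)[C@H]2CC[C@@]1(C)O)CC/C=C(\C)C(=O)OCc1cn(C[C@@H]2O[C@H](n3ccc(=O)[nH]c3=O)C[C@H]2O)nn1`: 148000 nM

Compound 2 has only a limit, > 150000 nM, and no number. That limit is the limit of > 150000 nM in this assay, at which 2 of the 3 values shown sit.

The next compound is compound 4 `C/C(=C\CC/C(C)=C/CC[C@@H]1[C@@]2(C)CCC(=O)C(C)(C)[C@H]2CC[C@@]1(C)O)CC/C=C(\C)C(=O)OCc1cn(-c2ccccc2C)nn1`, with the change methyl in place of nitro on an aromatic carbon, ortho to a large group. Within the data shown here, the one measured step, a step that the two limits leave unreadable from compound 1 to compound 2, has no readable size, so it sets no direction. Among the measured compounds shown here, compound 3 gives 148000 nM, but no step links it to this change. No step beyond the scatter is therefore expected in this assay. The expected step that the limit leaves unreadable from compound 2 to compound 4 is only a rough estimate. The estimate for compound 4 is 170000 nM, with an expected range of 100000 nM to 300000 nM.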

Compound 4, half-maximal inhibitory concentration: > 150000 nM
Compound 4: a limit, no number (the forecaster's own chance of this, stated with the estimate: 70%); the middle value does not contradict the limit.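

Compound 4 gives only a limit and no number, so no new step can be read from compound 1 or compound 2 to compound 4: the limit of > 150000 nM in this assay, at which 3 of the 4 values shown sit.

From the compounds shown here alone, the size of any effect of nitro to methyl in this assay stays open.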